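Hydrazone series: dropping one methoxy group from compound 1

The compounds below may be only part of what the source reports. "The series", "measured", "known", "first", "only" and "open" are said of these compounds alone.

Measured compounds:
- compound 1, `COc1cc(/C=N/N2C(=O)CSC2=S)cc(OC)c1O`; in a functional assay on cells (Mus musculus) for cytotoxicity, read by MTT assay, with a stated time of 24 h, tested at 10 uM (on this read-out lower numbers stand for a weaker effect and higher numbers for a stronger effect at the one concentration tested), compound 1 gives 85%
- compound 2, `COc1cc(/C=N/NC(=O)OCc2ccccc2)cc(OC)c1OC`; in this assay compound 2 gives 4%
- compound 3, `COc1cc(/C=N/Nc2nc3ccccc3s2)ccc1O`; in this assay compound 3 gives 61%

Compound 1 stands highest of the three numbers in this assay. Compound 3 comes nearest, lower by a gap beyond the scatter, and compound 2 lies furthest, lower by a gap far beyond it. For the measured compounds named here, no two of the measured compounds differ in a single place, so no single step between measured compounds is available for guidance.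

Compound 4, `COc1cc(/C=N/N2C(=O)CSC2=S)ccc1O`, has not yet been measured in this assay. It differs from compound 1 in one place: hydrogen in place of methoxy on an aromatic carbon. Compound 3 also pairs a hydroxy group with a single methoxy group and still gives 61% in this assay, though its other half is different, so that number is only a loose pointer. For compound 4 a moderate fall is expected, a number 15 percentage points lower from compound 1 to compound 4 (beyond the scatter), with a fair chance that it stays within the scatter. Compound 4 is estimated at 70% in this assay, with a range from 45% to 90%.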

Compound 4, a percentage reported as activity, at one concentration (the size of the read-out at that concentration, not a potency) in the Mus musculus assay: 72%
Estimate against measurement, compound 4: 2 percentage points below; low and high end bracket the measured number.
By their numbers in the Mus musculus assay, from the lowest: compound 2; then compound 3; then compound 4; then compound 1.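

In the Mus musculus assay, the swap of methoxy for hydrogen gives a number 13 percentage points lower from compound 1 to compound 4 (beyond the scatter), so this position, ortho to a hydroxy group, has a modest but real bearing on the read-out, and the second methoxy group is not essential to a high number. In a physicochemical assay on cells (Homo sapiens), with a stated time of 18 h, tested at 10 uM (on this read-out higher numbers stand for a weaker effect at the one concentration tested and lower numbers for a stronger effect), the same swap gives no change at the digits printed from compound 1 to compound 4 (within the scatter), with compound 1 at 5% and compound 4 at 5%, so the change registers in only one of the two read-outs. Nothing measured here accounts for this step or for the difference between the read-outs.

Still open, as far as these compounds go, is what an amine or an ethoxy group at this position would give in the Mus musculus assay and the Homo sapiens assay. From the compounds shown here alone, the step also rests on a single pair, so whether it carries over to compounds with a different other half remains unknown.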